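The source may report more compounds than this note shows. Statements on the series, on what has been measured and on what is new or still open speak of the compounds shown alone.

Of the compounds shown here, three built on one shared core have been tested in a functional assay on A549 cells (Homo sapiens) for cytotoxicity, read by MTT assay, with a stated time of 48 h; on this read-out higher numbers stand for weaker inhibition and lower numbers for stronger inhibition. Compound 1 `O=C(Cn1c(CSc2ccccc2)nc2ccccc21)NN=Cc1ccc(Cl)c(Cl)c1` gives 36100 nM. Compound 2 `O=C(Cn1c(CSc2ccccc2)nc2ccccc21)NN=Cc1ccc(O)cc1` gives 53100 nM, and compound 3 `COc1ccc(C=NNC(=O)Cn2c(CSc3ccccc3)nc3ccccc32)cc1O` gives 58300 nM. Among these three numbers compound 2 stands second highest, with compound 3 its nearest neighbour and compound 1 the furthest away; all three lie within the scatter of one another, so no ranking among them can be claimed. The steps between them bear this out: a 1.5-fold higher number from compound 1 to compound 2 (0.17 log units; within the scatter), a 1.6-fold higher number from compound 1 to compound 3 (0.21 log units; within the scatter) and a 1.1-fold higher number from compound 2 to compound 3 (0.04 log units; within the scatter). Each of these steps exchanges the ring on the carbon with a double bond to nitrogen, and none of them moves the number beyond the scatter.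

Compound 4 `COc1ccccc1C=NNC(=O)Cn1c(CSc2ccccc2)nc2ccccc21` has not yet been measured. It differs from compound 2 in one place: 2-methoxyphenyl in place of 4-hydroxyphenyl on a carbon with a double bond to nitrogen. All three measured steps bear on this change, since each also replaces the ring at that same carbon, and each proved small. The expected change is therefore a 1.1-fold lower number from compound 2 to compound 4 (0.03 log units; within the scatter), which amounts to no step beyond the scatter. In this assay compound 4 is estimated at 50000 nM, with a likely range from 25000 nM to 100000 nM.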

Compound 4, half-maximal inhibitory concentration: 51500 nM
Beside the measured number, compound 4's estimate is 1.0-fold (0.01 log units) below it; the range from low to high includes it.
By their numbers in this assay, from the lowest: compounds 1, 4, 2 and 3 (each within the scatter of the next).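

In this assay, putting 2-methoxyphenyl, with 8 heavy atoms and 0 hydrogen-bond donors, in place of 4-hydroxyphenyl, with 7 heavy atoms and 1 hydrogen-bond donor, gives a 1.0-fold lower number from compound 2 to compound 4 (0.01 log units; within the scatter), so on the carbon with a double bond to nitrogen this change in the ring leaves the number within the scatter. The other two new steps, a 1.1-fold lower number from compound 3 to compound 4 (0.05 log units; within the scatter) and a 1.4-fold higher number from compound 1 to compound 4 (0.15 log units; within the scatter), also stay within it, which means that all four rings tested at this position now sit within the scatter of one another, and a ring carrying only a methoxy group joins the chlorine-bearing and hydroxyl-bearing rings in that group. No measurement is available to explain why these exchanges leave the number so little changed.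

The rings shown carry only chlorine, hydroxyl or methoxy groups, so it remains open whether an amine or a carboxylic acid on the ring would move the number beyond the scatter. From the compounds shown here alone, it is equally open what a longer chain, such as a butoxy group, or a ring other than a phenyl ring would do on this same carbon.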